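Chain-end change from compound 1 to compound 3

The source may report more compounds than this note shows. Statements on the series, on what has been measured and on what is new or still open speak of the compounds shown alone.

For the measured compounds named here, compound 1 `CCOC(=O)CCCCOc1ccc2c(=O)c(-c3ccc(O)cc3)coc2c1` is measured in an assay (Cricetulus griseus) for inhibition of aldehyde dehydrogenase, mitochondrial (Homo sapiens) (on this read-out higher numbers stand for weaker inhibition and lower numbers for stronger inhibition), at 240 nM, the lowest of the two numbers so far. Compound 2 `CCCCC(Oc1ccc2c(=O)c(-c3ccc(O)cc3)coc2c1)C(=O)OCC` gives 4500 nM in this assay, a gap beyond the scatter. Compound 3 `O=C(O)CCCCCCOc1ccc2c(=O)c(-c3ccc(O)cc3)coc2c1` is built from compound 1 by one change: 2-carboxyethyl in place of ethoxycarbonyl on a saturated chain carbon, four bonds along the chain from an oxygen on an aromatic ring. Going by the values given here, no measured step bears on this change, so its size has to be guessed. The change is expected to weaken inhibition beyond the scatter, with an expected step of an 8.3-fold higher number from compound 1 to compound 3 (0.92 log units; beyond the scatter). Compound 3 is estimated at 2000 nM, within a range from 400 nM to 10000 nM.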

Compound 3, half-maximal inhibitory concentration: 50 nM
Compound 3: the middle estimate sits 40-fold (1.60 log units) above what was measured, and the stated range ends above it.
By their numbers in this assay, from the lowest: compound 3; then compound 1; then compound 2.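

In this assay the swap of ethoxycarbonyl for 2-carboxyethyl on a saturated chain carbon, four bonds along the chain from an oxygen on an aromatic ring, strengthens inhibition, with a 4.8-fold lower number from compound 1 to compound 3 (0.68 log units; beyond the scatter). This position therefore accepts a longer chain ending in a free carboxylic acid, and the ester is not needed for inhibition in this series. Nothing available explains the gain.

The step changes chain length and chain end together, leaving the share of each unresolved. A carboxylic acid on the shorter chain of compound 1, or an ethyl ester on the longer chain of compound 3, would separate the two.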